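Swapping a tert-butyl amide for a primary carboxamide

A few compounds are considered here, and "the series" means these few. Any claim that something is new, unique, unknown or untested is made for them only; others in the source may bear on it.

Compound 1, `CC(C)C[C@H](NC(=O)[C@]1(Cc2ccccc2)CCN1C(=O)OCc1ccccc1)C(N)=O`: 50000 nM
Compound 2, `CC(C)CNC(=O)[C@H](C)NC(=O)[C@]1(Cc2ccccc2)CCN1C(=O)OCc1ccccc1`: a limit of the assay, > 100000 nM
Compound 3, `C[C@H](NC(=O)[C@]1(Cc2ccccc2)CCN1C(=O)OCc1ccccc1)C(=O)NC(C)(C)C`: a limit of the assay, > 100000 nM

In an ADME assay on HELF cells (Homo sapiens) for cytotoxicity, with a stated time of 3 days (a lower number here means that less compound is tolerated, a higher number that more compound is tolerated), compound 1 gives 50000 nM. Compound 2 reaches only a limit of this assay, > 100000 nM. Compound 3 also reaches only a limit, > 100000 nM, so its standing on the numbers shown is a limit rather than a value, and it shares that position with one other compound (the limit of > 100000 nM in this assay, at which 2 of the 3 values shown sit).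

Compound 4, `CC(C)[C@H](NC(=O)[C@]1(Cc2ccccc2)CCN1C(=O)OCc1ccccc1)C(N)=O`, has not yet been measured. Its difference from compound 3 is 1-carbamoyl-2-methylpropyl in place of 1-((tert-butyl)carbamoyl)ethyl on an amide-type nitrogen. For the measured compounds named here, two measured steps bear on this change. Both an at least 2.0-fold higher number from compound 1 to compound 2 (0.30 log units; that floor lies within the scatter) and an at least 2.0-fold higher number from compound 1 to compound 3 (0.30 log units; that floor lies within the scatter) accompanied replacement of a primary carboxamide by a secondary amide, and both reached only a floor that lies within the scatter. The step that the two limits leave unreadable from compound 2 to compound 3 cannot be read. Going by the values given here, the move to compound 4 restores a primary carboxamide, so the number is expected to drift back toward that of compound 1, though no step clearly beyond the scatter supports a large shift. Compound 4 is therefore estimated at 70000 nM, between 30000 nM and 150000 nM, which as a step means an expected at least 1.4-fold lower number from compound 3 to compound 4 (0.15 log units; that floor lies within the scatter).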

Compound 4, half-maximal cytotoxic concentration: 100000 nM
The estimate for compound 4 lay 1.4-fold (0.15 log units) below the measured number; measured number inside the range.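

In this assay, isopropyl in place of isobutyl on a saturated chain carbon bound to an amide-type nitrogen and a carbonyl carbon comes with a 2.0-fold higher number from compound 1 to compound 4 (0.30 log units; within the scatter). With the primary carboxamide kept, the two branched chains therefore cannot be told apart at this place in this assay. Compound 1 and compound 4, both primary carboxamides, give numbers where compound 2 and compound 3, both secondary amides, give only limits. The size of the steps from those limits cannot be read, and they show only a number no higher from compound 3 to compound 4 (the limit leaves the size open) and a number no higher from compound 2 to compound 4 (the limit leaves the size open): the limit of > 100000 nM in this assay, at which 2 of the 4 values shown sit.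

From the compounds shown here alone, whether a carboxylic acid or an amine in place of the primary carboxamide would move the number beyond the scatter stays open, as does the effect of a longer chain or a cyclohexyl group in place of isopropyl. Also open, going by these compounds, is how far the true numbers for compound 2 and compound 3 lie from that of compound 4, and so whether the change of amide carries any real step in this assay.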